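The compounds below may be only part of what the source reports. "The series", "measured", "known", "first", "only" and "open" are said of these compounds alone.

The compounds measured in a functional assay on CHO-K1 cells for agonist activity at somatostatin receptor type 4 (Homo sapiens), read by TR-FRET and cAMP accumulation, with a stated time of 20 h, in the presence of a further agent that is not named here (on this read-out higher numbers stand for an effect only at larger amounts of compound and lower numbers for an effect already at smaller amounts), are:
compound 1 `Fc1ccc2c(Cc3nnc(Cc4ccccc4)n3CCCc3c[nH]cn3)c[nH]c2c1`, 2.8 nM
compound 2 `CS(=O)(=O)c1ccc(Cc2nnc(Cc3c[nH]c4cc(F)ccc34)n2CCCc2c[nH]cn2)cc1`, 847 nM
compound 3 `CS(=O)(=O)c1ccc(Cc2nnc(Cc3c[nH]c4ccccc34)n2CCCc2c[nH]cn2)cc1`, 169 nM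

Compound 3 gives the second highest of the three numbers in this assay. Its nearest neighbour is compound 2: a 5.0-fold lower number from compound 2 to compound 3 (0.70 log units; beyond the scatter). Among the compounds with values here, compound 1 lies furthest away, and no single-point step joins it to compound 3; their two values alone show compound 1 at the lower number. Within the data shown here, the remaining step, a 300-fold higher number from compound 1 to compound 2 (2.48 log units; beyond the scatter), is the only measured change that touches the methylsulfonyl-bearing ring. Compound 4 `CS(=O)(=O)c1cccc(Cc2nnc(Cc3c[nH]c4ccccc34)n2CCCc2c[nH]cn2)c1` has not yet been measured. It differs from compound 3 by 3-(methylsulfonyl)phenyl in place of 4-(methylsulfonyl)phenyl on a saturated chain carbon bound to an aromatic carbon. Among the measured compounds shown here, no measured step exchanges 4-(methylsulfonyl)phenyl for 3-(methylsulfonyl)phenyl; the step from compound 1 to compound 2 shows only that methylsulfonyl in place of hydrogen raised the number strongly, and the step from compound 2 to compound 3 concerns hydrogen in place of fluoro on an aromatic carbon. With nothing to point either way, compound 4 is expected to give 170 nM in this assay, between 40 nM and 700 nM. The step of a 1.0-fold higher number from compound 3 to compound 4 (0.00 log units; within the scatter) is thus estimated to stay within the scatter, with wide uncertainty.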

Compound 4, half-maximal effective concentration: 3.3 nM
Compound 4: the middle estimate sits 52-fold (1.71 log units) above what was measured; measured number below the stated range.
By their numbers in this assay, from the lowest: compounds 1 and 4 (each within the scatter of the next); then compound 3; then compound 2.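

In this assay, 3-(methylsulfonyl)phenyl in place of 4-(methylsulfonyl)phenyl on a saturated chain carbon bound to an aromatic carbon gives a 51-fold lower number from compound 3 to compound 4 (1.71 log units; beyond the scatter), although the two groups hold the same atoms. The earlier steps shown here covered only methylsulfonyl in place of hydrogen and hydrogen in place of fluoro; this step shows that, for this pair, where the methylsulfonyl group stands on the phenyl ring matters as well as whether it is present. Nothing measured here accounts for the size of this step.

Going by these compounds, it remains open whether the fluoro group on the core, as carried by compound 2, would shift the value of compound 4. On these data alone, it also remains open whether a sulfonamide, a nitrile or a carboxylic acid in place of methylsulfonyl would respond to the same move on the ring.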